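This account rests on a few compounds, and the source may have more. Where it says the series, first, only, none or still open, it means among the compounds named here.

Measured compounds:

compound 1, `COc1cccc(F)c1C1CCN(c2ccn3c(CC4CC4)nnc3c2Cl)CC1`: in an ADME assay on a cell-free system (plasma, Homo sapiens) for protein binding (on this read-out higher numbers stand for a larger free fraction and lower numbers for a smaller free fraction), compound 1 reaches only the limit < 0.01.
compound 2, `COc1ccc(F)c(F)c1C1CCN(c2ccn3c(CC4CC4)nnc3c2Cl)CC1`: in this assay compound 2 likewise reaches only the limit < 0.01.
compound 3, `COc1c(F)cccc1C1CCN(c2ccn3c(CC4CC4)nnc3c2C(F)(F)F)CC1`: in this assay compound 3 also reaches only the limit < 0.01.

From compound 1 to compound 2 the change is fluoro in place of hydrogen on an aromatic carbon; the step it made in this assay is a step that the two limits leave unreadable from compound 1 to compound 2. The reason it cannot be read is the limit of < 0.01 in this assay, at which 3 of the 3 values shown sit. How the core of compound 3 differs from the core of compound 1 is not broken down here.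

Compound 4, `COc1c(F)ccc(F)c1C1CCN(c2ccn3c(CC4CC4)nnc3c2C(F)(F)F)CC1`, is not yet measured. It differs from compound 3 by fluoro in place of hydrogen on an aromatic carbon. This is the same kind of change as from compound 1 to compound 2, not the same: there the entering fluoro sat ortho to a fluoro group, meta to a large group and para to a methoxy group, whereas here it sits ortho to a large group, meta to a methoxy group and para to a fluoro group.

The step expected in this assay is a step that the limit leaves unreadable from compound 3 to compound 4, which rests on the limit of < 0.01 in this assay, at which 3 of the 3 values shown sit, and so is itself expected to stay unreadable. Compound 4 is estimated at 0.005, most likely reported again as a limit.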

Compound 4, unbound fraction: < 0.01
Compound 4: a limit, no number (the forecaster's own chance of this, stated with the estimate: 85%); the middle value lies beyond the limit too.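

No step from compound 3 to compound 4 can be read in this assay, because both values stop at the same limit: the limit of < 0.01 in this assay, at which 4 of the 4 values shown sit.

The compounds shown leave open how far each of the four lies past that limit, and whether 3-fluoro-2-methoxyphenyl to 3,6-difluoro-2-methoxyphenyl changes the free fraction at all.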